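Lipophilicity of a Triazolopyrimidine Series: From Anilide to Spiro Lactam

The source may report more compounds than this note shows. Statements on the series, on what has been measured and on what is new or still open speak of the compounds shown alone.

Measured so far:
compound 1 `O=C(Nc1ccccc1)c1cnc(NCc2c(F)ccc3c2CCO3)n2cnnc12` gives 4.1
compound 2 `O=C1c2ccccc2CN1c1cnc(NCc2c(F)ccc3c2CCO3)n2cnnc12` gives 2.7
compound 3 `CN(c1ccccc1)c1cnc(NCc2c(F)ccc3c2CCO3)n2cnnc12` gives 3.6

All three were measured in a physicochemical assay for lipophilicity, using the shake flask method, in phosphate buffer, measured as octanol-water partition, with a stated time of 30 min, at pH 7.4; on this read-out lower numbers stand for lower lipophilicity and higher numbers for higher lipophilicity. Compound 3 stands second highest of the three: compound 1 sits a number 0.50 log units lower from compound 1 to compound 3 (beyond the scatter) away, and compound 2 is the furthest, with a number 0.90 log units higher from compound 2 to compound 3 (beyond the scatter).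

Compound 4 `O=C1CC2(CC2)CN1c1cnc(NCc2c(F)ccc3c2CCO3)n2cnnc12` has not yet been measured. It differs from compound 3 in one place: a group of 8 heavy atoms (6 carbon, 1 nitrogen, 1 oxygen; one three-membered non-aromatic ring of carbon only, one five-membered non-aromatic ring with 1 hetero atom) in place of a group of 8 heavy atoms (7 carbon, 1 nitrogen; one six-membered aromatic ring of carbon only), on an aromatic carbon The entering group has one three-membered non-aromatic ring of carbon only and one five-membered non-aromatic ring with 1 hetero atom, where compound 3 carries one six-membered aromatic ring of carbon only.

For the measured compounds named here, two measured steps bear on this change. Going from the anilide to a five-membered ring lactam gave a number 1.40 log units lower from compound 1 to compound 2 (beyond the scatter), a large drop. Going from that lactam to methyl(phenyl)amino gave a number 0.90 log units higher from compound 2 to compound 3 (beyond the scatter). Compound 4 again carries a five-membered ring lactam, but without any aromatic ring in that group, so a drop at least as large as the reverse of that second step is expected, a number 1.40 log units lower from compound 3 to compound 4 (beyond the scatter).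

The estimate for compound 4 in this assay is therefore 2.2, expected to lie between 1.5 and 2.9.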

Compound 4, distribution coefficient: 1.9
Estimate against measurement, compound 4: 0.30 log units above; the measured number falls inside the stated range.
By their numbers in this assay, from the lowest: compound 4; then compound 2; then compound 3; then compound 1.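

In this assay, for the compounds shown here, the group on this aromatic carbon can take the number lower than the earlier compounds showed: the group with a three-membered and a five-membered non-aromatic ring, and no aromatic ring, gives a number 1.70 log units lower from compound 3 to compound 4 (beyond the scatter) and also a number 2.20 log units lower from compound 1 to compound 4 (beyond the scatter) at the far end of the series. Among the two groups built on a five-membered non-aromatic ring, the one with the three-membered ring in place of the six-membered aromatic ring gives a number 0.80 log units lower from compound 2 to compound 4 (beyond the scatter) and so stands lowest of all four. Nothing measured here explains these shifts.

The compounds shown do not separate the effect of the three-membered ring from that of the rest of the group. Also open, going by these compounds, is where a simple five-membered lactam without that ring, a morpholine or a carboxylic acid on this carbon would fall.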